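A few compounds are considered here, and "the series" means these few. Any claim that something is new, unique, unknown or untested is made for them only; others in the source may bear on it.

Among the measured compounds shown here, compound 2 is the stronger inhibitor of the two measured so far: in a functional assay on HeLa cells (Homo sapiens) for antiproliferative activity, read by MTT assay, with a stated time of 48 h (a higher number here means a weaker inhibitor, a lower number a stronger inhibitor), compound 2 (`C=C(/C(C)=C/c1ccc(OC)c(O)c1)c1cc(OC)c(OC)c(OC)c1`) gives 60 nM against compound 1 (`CC=C(/C=C/c1ccc(OC)c(N)c1)c1cc(OC)c(OC)c(OC)c1`) with 217 nM and that gap lies beyond the scatter. Compound 3 (`CC=C(/C(C)=C/c1ccc(OC)c(O)c1)c1cc(OC)c(OC)c(OC)c1`) differs from compound 2 in one place (methyl in place of hydrogen on a double-bonded chain carbon bound to a double-bonded chain carbon): methyl in place of hydrogen on a double-bonded chain carbon bound to a double-bonded chain carbon. For the measured compounds named here, no measured pair shows this change alone, so only a small weakening is expected, one that may stay within the scatter, with a 1.5-fold higher number from compound 2 to compound 3 (0.18 log units; within the scatter) as the estimated step. In this assay compound 3 is expected near 90 nM within an estimated range of 25 nM to 300 nM for now.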

Compound 3, half-maximal inhibitory concentration: 563 nM
The estimate for compound 3 lay 6.3-fold (0.80 log units) below the measured number; the measured number lies above the stated range.
By their numbers in this assay, from the lowest: compound 2; then compound 1; then compound 3.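

In this assay, methyl in place of hydrogen on a double-bonded chain carbon bound to a double-bonded chain carbon proves to be no minor edit: it gives a 9.4-fold higher number from compound 2 to compound 3 (0.97 log units; beyond the scatter), a step beyond the scatter. A single added carbon at this place is therefore enough to weaken compound 2 clearly. Nothing at hand explains this loss.

As far as these compounds go, whether an ethyl group or a fluorine atom at this place would weaken compound 2 as much remains open. A single pair also cannot show whether the step would recur on another core.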